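This account rests on a few compounds, and the source may have more. Where it says the series, first, only, none or still open, it means among the compounds named here.

Among the measured compounds shown here, compound 3 `Cc1ccc(Cn2cncc2-c2cc3cc(Br)ccc3[nH]2)cc1` is one of three compounds measured in an assay on HEK293 cells for inhibition of Indoleamine 2,3-dioxygenase 1 (Homo sapiens), with a stated time of 30 min; on this read-out lower numbers stand for an effect already at smaller amounts and higher numbers for an effect only at larger amounts of compound. Compound 1 `Brc1ccc2[nH]c(-c3cncn3Cc3ccccc3)cc2c1` gives 11000 nM, compound 2 `Brc1ccc2[nH]c(-c3cncn3Cc3ccc(-c4ccccc4)cc3)cc2c1` gives 3090 nM, and compound 3 gives 4290 nM. Compound 3 thus carries the second highest of the three numbers; its nearest neighbour is compound 2, and the step of a 1.4-fold higher number from compound 2 to compound 3 (0.14 log units; within the scatter) lies within the scatter, while the step of a 2.6-fold lower number from compound 1 to compound 3 (0.41 log units; beyond the scatter) to the furthest, compound 1, is beyond it.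

Compound 4 `Nc1ccccc1Cn1cncc1-c1cc2cc(Br)ccc2[nH]1` is not yet measured. It differs from compound 3 by 2-aminophenyl in place of 4-methylphenyl on a saturated chain carbon bound to an aromatic nitrogen.

For the measured compounds named here, two measured steps touch the same region of the molecule: a 2.6-fold lower number from compound 1 to compound 3 (0.41 log units; beyond the scatter) and a 3.6-fold lower number from compound 1 to compound 2 (0.55 log units; beyond the scatter), both modest. They show only that methyl in place of hydrogen on an aromatic carbon or phenyl in place of hydrogen on an aromatic carbon lowers the number somewhat relative to compound 1, and that methyl in place of phenyl on an aromatic carbon makes no difference beyond the scatter. Going by the values given here, no measured step covers an amino group or the loss of the methyl. The change from compound 3 to compound 4 is therefore expected to give no step beyond the scatter, or at most a small one in either direction, so compound 4 is estimated at 6000 nM, within 2000 nM to 18000 nM, which means an expected step of a 1.4-fold higher number from compound 3 to compound 4 (0.15 log units; within the scatter).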

Compound 4, half-maximal effective concentration: 12000 nM
The estimate for compound 4 lay 2.0-fold (0.30 log units) below the measured number; the measured number falls inside the stated range.
By their numbers in this assay, from the lowest: compounds 2 and 3 (each within the scatter of the next); then compounds 1 and 4 (each within the scatter of the next).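

In this assay, the place on a saturated chain carbon bound to an aromatic nitrogen proves sensitive to more than the size of the group: 2-aminophenyl and 4-methylphenyl both count the same heavy atoms, yet the exchange gives a 2.8-fold higher number from compound 3 to compound 4 (0.45 log units; beyond the scatter). Adding an amino group to the ring gives a 1.1-fold higher number from compound 1 to compound 4 (0.04 log units; within the scatter), so this substituent does not share the modest lowering seen with methyl in a 2.6-fold lower number from compound 1 to compound 3 (0.41 log units; beyond the scatter) and with phenyl in a 3.6-fold lower number from compound 1 to compound 2 (0.55 log units; beyond the scatter), and the series now shows that a substituent on this phenyl ring does not always lower the number. Nothing available accounts for the difference between the amino and methyl compounds.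

The step from compound 3 to compound 4 changes both the group and its place on the ring, so it leaves unresolved which of the two matters; 2-methylphenyl and 4-aminophenyl would separate them. Also open, as far as these compounds go, is how a carboxylic acid or a methoxy group on this ring would read, and whether a longer chain at this place would change the picture.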